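The source may hold more compounds than are shown below. What is called first, only, known or untested is meant among the compounds shown, and "the series" means these compounds.

Measured in a functional assay on CEM-DNR-bulk cells (Homo sapiens), read by MTT assay, with a stated time of 72 h; a lower number here means a stronger inhibitor, a higher number a weaker inhibitor:
Compound 1 `C#Cc1cn([C@@H]2O[C@H](CO)[C@@H](O)[C@H]2O)c2ncnc(NC)c12`: 18500 nM
Compound 2 `Cc1ncnc2c1c(-c1cc3ccccc3o1)cn2[C@@H]1O[C@H](CO)[C@@H](O)[C@H]1O`: > 20000 nM (a limit of the assay)

Compound 2 gives no number in this assay, only a limit. As far as these compounds go, it stands at the limit of > 20000 nM in this assay, at which 1 of the 2 values shown sits, so how weak it really is remains unknown.

The next compound is compound 3 `C#Cc1cn([C@@H]2O[C@H](CO)[C@@H](O)[C@H]2O)c2ncnc(C)c12`. The change is ethynyl in place of 1-benzofuran-2-yl on an aromatic carbon of a five-membered aromatic ring with 1 nitrogen.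

Among the measured compounds shown here, no step between measured compounds gives the size of this change directly. For the measured compounds named here, the only guide is compound 1, which also carries an ethynyl group and gives 18500 nM in this assay. On that basis, a moderate move toward stronger inhibition is expected, though compound 3 may well stay near the limit of the assay. The expected size of the change is an at least 2.5-fold lower number from compound 2 to compound 3 (0.39 log units; beyond the scatter). For compound 3 the estimated value is 8000 nM, with an expected range from 1000 nM to 20000 nM.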

Compound 3, half-maximal inhibitory concentration: 160 nM
Estimate against measurement, compound 3: 50-fold (1.70 log units) above, and the stated range ends above it.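

In this assay, ethynyl in place of 1-benzofuran-2-yl on an aromatic carbon of the five-membered aromatic ring with 1 nitrogen gives an at least 120-fold lower number from compound 2 to compound 3 (2.09 log units; beyond the scatter). This shows that the position can carry a group that gives a far stronger inhibitor, which compound 2 alone could not show, and the size of the step has only a lower bound, compound 2 being held as a limit: the limit of > 20000 nM in this assay, at which 1 of the 3 values shown sits. Ethynyl alone does not set the level either, for with ethynyl kept, methyl in place of methylamino on an aromatic carbon gives a 120-fold lower number from compound 1 to compound 3 (2.06 log units; beyond the scatter), so a second place in the shared core also carries a large effect.

As far as these compounds go, it remains open whether the gain at the first position belongs to ethynyl itself or would also come with a bromine atom, a cyano group or a short chain such as ethyl at that carbon. From the compounds shown here alone, it is equally open how a chlorine atom, a methoxy group or a dimethylamino group would compare with methyl at the second place.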